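The source may report more compounds than this note shows. Statements on the series, on what has been measured and on what is new or still open speak of the compounds shown alone.

Compound 1 `CCCCOC(=O)CCC(=O)N1CCN(CCCOc2cc3c(Nc4ccc(F)c(Cl)c4)ncnc3cc2OC)CC1` gives 64.1% in a functional assay on A549 cells (Homo sapiens) for cytotoxicity, read by MTT assay, with a stated time of 24 h, tested at 60 uM; a higher number here means a weaker effect of the compound at the concentration tested, a lower number a stronger effect.
Compound 2 `CCCCCCOC(=O)CCC(=O)N1CCN(CCCOc2cc3c(Nc4ccc(F)c(Cl)c4)ncnc3cc2OC)CC1` gives 63.6% in this assay.
Compound 3 `CCCCCCCCCCCOC(=O)CCC(=O)N1CCN(CCCOc2cc3c(Nc4ccc(F)c(Cl)c4)ncnc3cc2OC)CC1` gives 3.9% in this assay.

Among these three, compound 3 stands lowest: its nearest neighbour is compound 2, and its furthest is compound 1, both beyond the scatter. Compound 4 `CCCCCCCCCCCCOC(=O)CCC(=O)N1CCN(CCCOc2cc3c(Nc4ccc(F)c(Cl)c4)ncnc3cc2OC)CC1` has not yet been measured. It differs from compound 3 by one small change: methyl in place of hydrogen on a saturated chain carbon, ten or more bonds along the chain from an oxygen next to a carbonyl group.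

Going by the values given here, two measured steps bear on this chain lengthening. The step of a number 60.2 percentage points lower from compound 1 to compound 3 (beyond the scatter) and the step of a number 59.7 percentage points lower from compound 2 to compound 3 (beyond the scatter) were both large drops, while the step of a number 0.5 percentage points lower from compound 1 to compound 2 (within the scatter) lay within the scatter. So a longer chain has gone with a much lower number here, but compound 3 already sits close to the floor of what this read-out can show, and adding one methyl is the smallest possible lengthening. The step of a number 0.9 percentage points lower from compound 3 to compound 4 (within the scatter) is therefore expected to be small, within the scatter. Compound 4 is expected to give about 3%, between 0% and 12%.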

Compound 4, a percentage reported as activity, at one concentration (the size of the read-out at that concentration, not a potency): 2%
For compound 4 the middle estimate is 1 percentage points above the measured one; measured number inside the range.
By their numbers in this assay, from the lowest: compounds 4 and 3 (each within the scatter of the next); then compounds 2 and 1 (each within the scatter of the next).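

In this assay, methyl in place of hydrogen on a saturated chain carbon, ten or more bonds along the chain from an oxygen next to a carbonyl group, gives a number 1.9 percentage points lower from compound 3 to compound 4 (within the scatter), so this extra carbon adds nothing the read-out can separate. The large gap to the shorter esters holds for the new compound too: hexyl in place of hydrogen six bonds along the chain gives a number 61.6 percentage points lower from compound 2 to compound 4 (beyond the scatter), and octyl in place of hydrogen four bonds along the chain gives a number 62.1 percentage points lower from compound 1 to compound 4 (beyond the scatter). Nothing measured here offers a cause for these steps.

Where the drop sets in among the chain lengths from compound 2 to compound 3 remains open. So does whether a longer chain, or an amine or a carboxylic acid carried on this chain, would give a similar number.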